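The source may report more compounds than this note shows. Statements on the series, on what has been measured and on what is new or still open speak of the compounds shown alone.

Compound 1 `C=CCc1cc(C(C)=O)c(O)cc1OCC#N` gives 2% in an assay on isolated protein for binding affinity to leukotriene B4 receptor 1 (Homo sapiens), tested at 1 uM; on this read-out higher numbers stand for more inhibition at the one concentration tested (going by the name of the read-out) and lower numbers for less inhibition.
Compound 2 `C=CCc1cc(C(C)=O)c(O)cc1OCCCC#N` gives 6%.
Compound 3 `C=CCc1cc(C(C)=O)c(O)cc1OCCCC` gives 8%.

Compound 3 sits at the top of the three numbers as written, yet the gaps to the others, a number 6 percentage points higher from compound 1 to compound 3 (within the scatter) and a number 2 percentage points higher from compound 2 to compound 3 (within the scatter), are within the scatter, so the three compounds cannot be told apart. Compound 4 `C=CCc1cc(C(C)=O)c(O)cc1OCCCCO` differs from compound 3 by hydroxy in place of hydrogen on a saturated chain carbon, four bonds along the chain from an oxygen on an aromatic ring. Among the measured compounds shown here, no measured step adds a hydroxy at that place; the closest comparisons are the changes at the end of the same chain, a number 4 percentage points higher from compound 1 to compound 2 (within the scatter) and a number 2 percentage points higher from compound 2 to compound 3 (within the scatter), both within the scatter. No step beyond the scatter is therefore expected in this assay, no change at the digits printed from compound 3 to compound 4 (within the scatter). Compound 4 is estimated at 8%, between 0% and 18%.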

Compound 4, a percentage reported as inhibition, at one concentration (the size of the read-out at that concentration, not a potency): 9%
Estimate against measurement, compound 4: 1 percentage points below; measured number inside the range.
By their numbers in this assay, from the lowest: compounds 1, 2, 3 and 4 (each within the scatter of the next).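

Hydroxy in place of hydrogen on this saturated chain carbon, four bonds along the chain from an oxygen on an aromatic ring, brings in a hydrogen-bond donor and acceptor, yet in this assay it gives a number 1 percentage points higher from compound 3 to compound 4 (within the scatter). Comparing the alcohol with the cyano chains gives a number 3 percentage points higher from compound 2 to compound 4 (within the scatter) and a number 7 percentage points higher from compound 1 to compound 4 (within the scatter), so cyano, alkyl and hydroxy chain ends cannot be told apart here. Nothing available offers a reason for this.

On these data alone, whether an amine or a carboxylic acid at the chain end would change the number remains open. So does the effect of changes elsewhere on the shared core.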